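The source may report more compounds than this note shows. Statements on the series, on what has been measured and on what is new or still open speak of the compounds shown alone.

Measured so far:
- compound 1 `CN(C)CCN(CCN(C)C)c1cccc(C(=O)N2CCc3ccc(OS(N)(=O)=O)cc3C2)c1`: 17.1%
- compound 2 `NS(=O)(=O)Oc1ccc2c(c1)CN(C(=O)c1cccc(N3CCc4ccccc4C3)c1)CC2`: 50.2%

In an assay on HEK293 cells for inhibition of Steryl-sulfatase (Homo sapiens), tested at 1 uM (a lower number here means a weaker effect, a higher number a stronger effect of the compound at the concentration tested), compound 2 gives 50.2%, the higher of the two numbers; compound 1 gives 17.1%. Going by the values given here, the only step available is a number 33.1 percentage points higher from compound 1 to compound 2 (beyond the scatter), a large gain on moving from an amine with no ring to one carrying rings.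

Compound 3 `CCCN(CCC)c1cccc(C(=O)N2CCc3ccc(OS(N)(=O)=O)cc3C2)c1` differs from compound 2 by dipropylamino in place of 1,2,3,4-tetrahydroisoquinolin-2-yl on an aromatic carbon. That change brings back an amine with no ring, partly reversing the step just named, so a decrease in this assay is expected, a number 20.2 percentage points lower from compound 2 to compound 3 (beyond the scatter). Compound 3 is estimated at 30% (range 12% to 50%).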

Compound 3, a percentage reported as inhibition, at one concentration (the size of the read-out at that concentration, not a potency): 54.8%
For compound 3 the middle estimate is 24.8 percentage points below the measured one; the measured number lies above the stated range.
By their numbers in this assay, from the lowest: compound 1; then compounds 2 and 3 (each within the scatter of the next).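

In this assay, the change at this aromatic carbon gives a number 4.6 percentage points higher from compound 2 to compound 3 (within the scatter), so a ring on the amine is not required here: dipropylamino and 1,2,3,4-tetrahydroisoquinolin-2-yl cannot be told apart. With a number 37.7 percentage points higher from compound 1 to compound 3 (beyond the scatter), the low number of compound 1 goes with bis(2-(dimethylamino)ethyl)amino specifically, not with the absence of a ring. No data at hand bear on why these amines differ.

Still open, as far as these compounds go, is how a shorter chain such as diethylamino or a simple ring such as piperidin-1-yl would compare. A single 2-(dimethylamino)ethyl arm paired with a propyl chain would test whether one such arm already lowers the number.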